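Series notes: hydrogen in place of methoxy

A few compounds are considered here, and "the series" means these few. Any claim that something is new, unique, unknown or untested is made for them only; others in the source may bear on it.

Two compounds have numbers in a functional assay on the whole organism (strain Wistar albino) for inhibition, with Rattus norvegicus as the target, read by paw edema, with stated times of 30 min and 1 h, at a dose of 20 mg/kg; a higher number here means more inhibition at the dose given (going by the name of the read-out), a lower number less inhibition. Compound 1 `Clc1ccc([C@H]2CC(c3ccccc3)=NN2c2ncc(Br)cn2)cc1` gives 70% in this assay. Compound 2 `COc1ccc([C@H]2CC(c3ccc(Cl)cc3)=NN2c2ncc(Br)cn2)cc1` gives 62%, the lowest of the two numbers, with compound 1 as the nearest and within the scatter of it. Compound 3 `Clc1ccc(C2=NN(c3ncc(Br)cn3)[C@@H](c3ccccc3)C2)cc1` is not yet measured and differs from compound 2 by hydrogen in place of methoxy on an aromatic carbon. Within the data shown here, no step between measured compounds is available to size this change. The step of a number 4 percentage points higher from compound 2 to compound 3 (within the scatter) is expected to be small, none beyond the scatter, in either direction. Compound 3 is expected to give 66% in this assay, within 54% to 78%.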

Compound 3, a percentage reported as inhibition, in the whole organism at one dose (the size of the read-out at that dose, not a potency): 71%
Beside the measured number, compound 3's estimate is 5 percentage points below it, and the stated range covers the measured number.
By their numbers in this assay, from the lowest: compounds 2, 1 and 3 (each within the scatter of the next).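

In this assay the change from 4-methoxyphenyl to phenyl reads a number 9 percentage points higher from compound 2 to compound 3 (within the scatter) and gives the first direct size for this change on an aromatic carbon, para to a large group. At this place, methoxy is not required for the inhibition seen at the dose given, and its replacement by hydrogen leaves the read-out within the scatter. As far as these compounds go, whether an amine, a carboxylic acid or a longer alkoxy chain here would move the read-out beyond the scatter remains open. No measurement at hand explains why the read-out holds across this change.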